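The compounds below may be only part of what the source reports. "The series", "measured", "known", "first", "only" and "open" are said of these compounds alone.

Compound 3 `O=C(N[C@H]1CC[C@@H](c2ccccc2)CC1)c1[nH]c(=O)[nH]c(=O)c1NC1CCCC1` gives 156 nM in an assay on cells for inhibition of endothelial lipase (Homo sapiens), read by LC-MS, with stated times of 10 min and 30 min (on this read-out lower numbers stand for stronger inhibition and higher numbers for weaker inhibition), the highest of the three numbers shown. Compound 1 `Nc1c(C(=O)N[C@H]2CC[C@@H](c3ccccc3)CC2)[nH]c(=O)[nH]c1=O` gives 91 nM in this assay, and compound 2 `Nc1c(C(=O)N[C@@H]2CC[C@H](c3ccccc3)c3ccccc32)[nH]c(=O)[nH]c1=O` gives 50 nM; the step of a 1.7-fold higher number from compound 1 to compound 3 (0.23 log units; within the scatter) is within the scatter, whereas the two values of compound 3 and compound 2 lie beyond it. Compound 4 `O=C(N[C@H]1CC[C@@H](c2ccccc2)CC1)c1[nH]c(=O)[nH]c(=O)c1O` carries hydroxy in place of cyclopentylamino on an aromatic carbon. Going by the values given here, only one measured step touches this position, and it was small; no measured step trades the amino-bearing group for hydroxy, so the direction here stays open. Compound 4 is therefore expected to move little, by a 1.0-fold lower number from compound 3 to compound 4 (0.02 log units; within the scatter), with an estimated value of 150 nM and a range from 40 nM to 600 nM.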

Compound 4, half-maximal inhibitory concentration: 26 nM
Estimate against measurement, compound 4: 5.8-fold (0.76 log units) above; measured number outside the range, below it.
By their numbers in this assay, from the lowest: compounds 4, 2, 1 and 3 (each within the scatter of the next, the first and the last beyond it).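

At this position on the core, hydroxy gives a lower number in this assay than either nitrogen-bearing group, beyond the scatter in both steps: a 6.0-fold lower number from compound 3 to compound 4 (0.78 log units; beyond the scatter) and a 3.5-fold lower number from compound 1 to compound 4 (0.54 log units; beyond the scatter). The earlier step of a 1.7-fold higher number from compound 1 to compound 3 (0.23 log units; within the scatter) had shown no change beyond the scatter, so this position does respond to the group it carries. Nothing available explains that response.

Going by these compounds, whether methoxy, fluorine or a carboxylic acid would give similar numbers here stays open. So does whether hydroxy would have the same effect on the core of compound 2.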